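The compounds below may be only part of what the source reports. "The series", "measured", "known", "first", "only" and "open" are said of these compounds alone.

Of the compounds shown here, three have been tested in an ADME assay on HeLa cells (Homo sapiens) for cytotoxicity, read by ATP content, with a stated time of 3 days (a higher number here means that more compound is tolerated, a lower number that less compound is tolerated), and a fourth has not yet been measured. Compound 1 `CC(C)CCn1c(Cn2c(=O)n(C3CC3)c3ccncc32)nc2nc(Cl)ccc21` and compound 2 `CS(=O)(=O)CCCn1c(Cn2c(=O)n(C3CC3)c3ccncc32)nc2nc(Cl)ccc21` share one core, while compound 3 `CS(=O)(=O)CCCn1c(Cn2c(=O)n(C3CC3)c3ccncc32)cc2ccccc21` and compound 4 `CC(C)CCn1c(Cn2c(=O)n(C3CC3)c3ccncc32)cc2ccccc21` share another; the difference between the two cores is not broken down here.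

In this assay compound 1 gives > 50000 nM, which is a limit of the assay rather than a number. In this assay compound 2 gives > 50000 nM, again a limit. In this assay compound 3 gives > 100000 nM, also a limit. Two of the three values sit at the limit of > 50000 nM in this assay, at which 2 of the 3 values shown sit, and one at the limit of > 100000 nM in this assay, at which 1 of the 3 values shown sits, so none of them is a true number and no ordering among the three can be read from them.

The change from compound 2 to compound 1 is isopropyl in place of (methylsulfonyl)methyl on a saturated chain carbon, two bonds along the chain from an aromatic nitrogen and its step is a step that the two limits leave unreadable from compound 2 to compound 1. The same change, at the same place, leads from compound 3 to compound 4: isopropyl in place of (methylsulfonyl)methyl on a saturated chain carbon, two bonds along the chain from an aromatic nitrogen. Compound 3 and compound 4 therefore stand to each other as compound 2 and compound 1 do, only on the other core.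

Because the measured step that the two limits leave unreadable from compound 2 to compound 1 could not be read between two limits, the expected step here is a step that the limit leaves unreadable from compound 3 to compound 4, that is, essentially no change. For compound 4 the expected value in this assay is 150000 nM, with the most likely outcome being that the assay again reports only a limit.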

Compound 4, half-maximal cytotoxic concentration: > 100000 nM
Compound 4 was reported as a limit; the forecaster's own chance of this, stated with the estimate: 85%; the middle value does not contradict the limit.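

In this assay compound 4 gives > 100000 nM, a limit of the assay and not a number. No new step can be read between compound 3 and compound 4, because both stop at the same limit: the limit of > 100000 nM in this assay, at which 2 of the 4 values shown sit.

The compounds shown leave open at what concentration any of the four would harm the cells, and whether replacing 3-(methylsulfonyl)propyl with isopentyl changes how much compound is tolerated on either core.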